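A few compounds are considered here, and "the series" means these few. Any claim that something is new, unique, unknown or untested is made for them only; others in the source may bear on it.

Measured so far in an ADME assay on microsomes from liver (Rattus norvegicus) for metabolic stability, read by LC-MS, using NADPH, tested at 3 uM; a higher number here means that the compound lasts longer, a lower number that the compound disappears faster:
- compound 1 `Cc1ccc2c(C(c3cccs3)C(C#N)C#N)c(-c3ccccc3)[nH]c2c1`: 0.0817 h
- compound 2 `Cc1ccc2c(C(CC(F)(F)F)c3cccs3)c(-c3ccccc3)[nH]c2c1`: 0.292 h

Of these two compounds, compound 2 has the higher number, and so it lasts longer. Compound 3 `FC(F)(F)CC(c1cccs1)c1c(-c2ccccc2)[nH]c2cc(Cl)ccc12` keeps the core and side chain of compound 2 but carries chloro in place of methyl on an aromatic carbon. Going by the values given here, the only measured step, a 3.6-fold higher number from compound 1 to compound 2 (0.55 log units; beyond the scatter), is modest and lies at a saturated chain carbon, not on the aromatic carbon changed here. Among the compounds with values here, it therefore gives no direct guide to size or direction, and no measured pair covers this swap. Only a small rise, not beyond the scatter, is expected. The expected change is a 1.2-fold higher number from compound 2 to compound 3 (0.08 log units; within the scatter). For compound 3 the estimated half-life is 0.35 h, with an expected range of 0.15 h to 0.8 h.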

Compound 3, half-life: 0.905 h
For compound 3 the middle estimate is 2.6-fold (0.41 log units) below the measured one; measured number above the stated range.
By their numbers in this assay, from the lowest: compound 1; then compound 2; then compound 3.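

In this assay, going by these compounds alone, chloro in place of methyl on an aromatic carbon gives a 3.1-fold higher number from compound 2 to compound 3 (0.49 log units; beyond the scatter) and so shows that this carbon, unchanged between the earlier compounds, also bears on how long a compound lasts. Like the earlier step at the saturated chain carbon, this step is modest and beyond the scatter, and it also goes towards a higher number. Nothing measured here accounts for the effect of this swap.

The compounds shown leave open whether fluoro, methoxy or an amine on the same aromatic carbon would move the half-life as chloro does. They also leave open whether chloro in place of methyl would give a similar step with the dicyanomethyl side chain of compound 1.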